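Adding One Carbon to the Hydrazone of Compound 2

A few compounds are considered here, and "the series" means these few. Any claim that something is new, unique, unknown or untested is made for them only; others in the source may bear on it.

Compound 2, `CC1=CC[C@@H]([C@@](C)(O)CCCC(C)(C)NC(=S)N/N=C\c2ccccc2)CC1`, was tested in a functional assay on K562 cells (Homo sapiens) for cytotoxicity, read by sulforhodamine B assay (a higher number here means a weaker inhibitor of growth, a lower number a stronger inhibitor of growth), where compound 2 gives 130 nM. Among the three measured compounds this is the second highest number. Compound 3, `CC1=CC[C@@H]([C@@](C)(O)CCCC(C)(C)NC(=S)N/N=C\c2ccc(N(C)C)cc2)CC1`, gives 80 nM in this assay, and the step is a 1.6-fold lower number from compound 2 to compound 3 (0.21 log units; within the scatter). Compound 1, `CC1=CC[C@@H]([C@@](C)(O)CCCC(C)(C)NC=S)CC1`, the bare thioamide without the aromatic hydrazone part, gives 16700 nM, and the step is a 130-fold lower number from compound 1 to compound 2 (2.11 log units; beyond the scatter), a large one.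

Compound 4, `CC1=CC[C@@H]([C@@](C)(O)CCCC(C)(C)NC(=S)N/N=C(/C)c2ccccc2)CC1`, differs from compound 2 in one place: a group of 9 heavy atoms (8 carbon, 1 nitrogen; one six-membered aromatic ring of carbon only) in place of a group of 8 heavy atoms (7 carbon, 1 nitrogen; one six-membered aromatic ring of carbon only), on an amide-type nitrogen. The entering group carries one carbon more than the leaving group, while the aromatic ring and the double bond outside the ring are kept.

Among the compounds with values here, no measured step matches this change directly. The large step from compound 1 to compound 2 shows that the whole aromatic hydrazone part matters, while the small step from compound 2 to compound 3 shows that a change within that part stays within the scatter. Since compound 4 keeps the whole part, a step within the scatter is expected, a 1.2-fold higher number from compound 2 to compound 4 (0.06 log units; within the scatter). Compound 4 is therefore estimated at 150 nM, with a range from 60 nM to 400 nM.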

Compound 4, concentration for 50% growth inhibition: 10 nM
Compound 4: the middle estimate sits 15-fold (1.18 log units) above what was measured; measured number outside the range, below it.
By their numbers in this assay, from the lowest: compound 4; then compounds 3 and 2 (each within the scatter of the next); then compound 1.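

In this assay, the group on the amide-type nitrogen proves sensitive to a very small change: the group of 9 heavy atoms in place of the group of 8 heavy atoms gives a 13-fold lower number from compound 2 to compound 4 (1.11 log units; beyond the scatter). The earlier compounds shown here showed that the aromatic hydrazone part matters as a whole, and dimethylamino on an aromatic carbon gave only a 1.6-fold lower number from compound 2 to compound 3 (0.21 log units; within the scatter), whereas this result shows that a change within that part can also count for much, even with the aromatic ring and the double bond kept. No measurement available here accounts for the size of this step.

The compounds shown leave open whether an ethyl group or a longer chain in the same group would lower the number further. They also leave open whether dimethylamino on the aromatic ring of compound 4 would change its number.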